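Phenyl swap on the oxygen: notes toward compound 3

This account rests on a few compounds, and the source may have more. Where it says the series, first, only, none or still open, it means among the compounds named here.

In a functional assay with Homo sapiens as the target (on this read-out lower numbers stand for stronger inhibition and higher numbers for weaker inhibition), compound 2 `CC(C)[C@H](NC(=O)COc1cccc2ccccc12)C(=O)N[C@@H](CC(=O)O)C(=O)COc1ccc(C(F)(F)F)cc1` gives 12300 nM and compound 1 `CC(C)[C@H](NC(=O)COc1cccc2ccccc12)C(=O)N[C@@H](CC(=O)O)C(=O)COc1cccc(C(F)(F)F)c1` gives 16600 nM. Among the measured compounds shown here, these are the only two numbers so far, and they stand level within the scatter.

Compound 3 `CC(C)[C@H](NC(=O)COc1cccc2ccccc12)C(=O)N[C@@H](CC(=O)O)C(=O)COc1cccc(F)c1` has not yet been measured. It carries 3-fluorophenyl in place of 4-(trifluoromethyl)phenyl on an oxygen on a saturated carbon.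

For the measured compounds named here, the one measured step that bears on this, a 1.3-fold lower number from compound 1 to compound 2 (0.13 log units; within the scatter), exchanges 3-(trifluoromethyl)phenyl for 4-(trifluoromethyl)phenyl and stays within the scatter. Going by the values given here, no measured step exchanges trifluoromethyl for fluorine, so the data give no direction, and no change beyond the scatter is expected.

The expected step is a 1.1-fold higher number from compound 2 to compound 3 (0.06 log units; within the scatter).

Compound 3 is estimated at 14000 nM, with an expected range of 6000 nM to 32000 nM.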

Compound 3, half-maximal inhibitory concentration: 12000 nM
Beside the measured number, compound 3's estimate is 1.2-fold (0.07 log units) above it; the range from low to high includes it.
By their numbers in this assay, from the lowest: compounds 3, 2 and 1 (each within the scatter of the next).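

In this assay, the exchange of 4-(trifluoromethyl)phenyl for 3-fluorophenyl on the oxygen on a saturated carbon gives a 1.0-fold lower number from compound 2 to compound 3 (0.01 log units; within the scatter), so a change from 10 heavy atoms to 7 leaves the number unmoved beyond the scatter. Among the compounds shown here, the direct exchange of fluoro for trifluoromethyl on an aromatic carbon, with the 3-substituted phenyl kept, gives a 1.4-fold lower number from compound 1 to compound 3 (0.14 log units; within the scatter), again within the scatter and the first reading of this exchange. No measurement at hand accounts for this flat response.

The compounds shown leave open whether an amine or a carboxylic acid on this phenyl, or a longer chain in its place, would shift the number beyond the scatter. Going by these compounds, all three compounds share the rest of the structure, so whether the flat response holds on a different core also remains open.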